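A methoxy group on the anilino ring of compound 1

The source may report more compounds than this note shows. Statements on the series, on what has been measured and on what is new or still open speak of the compounds shown alone.

Going by the values given here, compound 1 `Cc1nc(SCC(=O)Nc2nc(-c3ccc(Cl)cc3)cs2)n(Nc2ccccc2)c1C` is the only member of this set with a number in a functional assay on IGROV-1 cells (Homo sapiens) for antiproliferative activity, read by sulforhodamine B assay, with a stated time of 48 h; a higher number here means a weaker inhibitor of growth, a lower number a stronger inhibitor of growth: compound 1 gives 20600 nM. Compound 2 `Cc1ccc(Nn2c(SCC(=O)Nc3nc(-c4ccccc4)cs3)nc(C)c2C)cc1` is reported only as a limit of the assay, > 100000 nM. Where that value sits is given by the limit of > 100000 nM in this assay, at which 1 of the 2 values shown sits. Among the compounds with values here, no step between compound 1 and compound 2 is reported; their two values show only that compound 2 fell outside the measurable range while compound 1 did not.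

Compound 3 `COc1ccc(Nn2c(SCC(=O)Nc3nc(-c4ccc(Cl)cc4)cs3)nc(C)c2C)cc1` differs from compound 1 by methoxy in place of hydrogen on an aromatic carbon, a single substitution on the anilino ring while the rest of the shared core is kept. Within the data shown here, with no measured step to lean on, the change is expected to move this assay toward weaker inhibition by a modest amount, beyond the usual scatter but not by a large margin. Compound 3 is therefore estimated at 40000 nM, with a range from 12000 nM to 150000 nM. The expected step is a 1.9-fold higher number from compound 1 to compound 3 (0.29 log units; within the scatter).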

Compound 3, concentration for total growth inhibition: > 100000 nM
Compound 3: no number, only a limit; the forecaster's own chance of this, stated with the estimate: 35%; middle value at least 2.5-fold (0.39 log units) from the limit.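

In this assay, going by these compounds alone, methoxy in place of hydrogen on the anilino ring gives the first measured step in this set, an at least 4.8-fold higher number from compound 1 to compound 3 (0.68 log units; beyond the scatter), and it shows that this place, para to a large group, is not neutral to the change. Compound 3 is reported only as a limit, > 100000 nM, so the step fixes a direction and a minimum size, not a full size. The set now leans towards such results: the limit of > 100000 nM in this assay, at which 2 of the 3 values shown sit.

On these data alone, whether a fluorine atom, a hydroxyl group or an amine at this same place would keep the growth inhibition of compound 1 remains open. So does whether the loss belongs to methoxy itself or to any group that replaces hydrogen here.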